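This account rests on a few compounds, and the source may have more. Where it says the series, first, only, none or still open, it means among the compounds named here.

Compound 2 `CCOC(=O)CN(Cc1ccccc1)c1nc(Nc2cc(OC)c(OC)c(OC)c2)ncc1[N+](=O)[O-]` was tested in a functional assay on MDA-MB-231 cells (Homo sapiens) for antiproliferative activity, read by MTT assay, with a stated time of 48 h (a lower number here means a stronger inhibitor, a higher number a weaker inhibitor), where compound 2 gives 40400 nM. Among the two numbers so far this is the lowest, but the only neighbour, compound 1 `CCOC(=O)CN(Cc1ccccc1)c1nc(NCc2cccc(OC)c2)ncc1[N+](=O)[O-]`, stands close: in this assay compound 1 gives 80700 nM, and the step of a 2.0-fold lower number from compound 1 to compound 2 (0.30 log units; within the scatter) lies within the scatter, so the two compounds cannot be ordered.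

The next compound, compound 3 `CCOC(=O)CNc1ncc([N+](=O)[O-])c(N(CC(=O)OCC)Cc2ccccc2)n1`, differs from compound 2 by (ethoxycarbonyl)methyl in place of 3,4,5-trimethoxyphenyl on a nitrogen on an aromatic ring. For the measured compounds named here, none of the measured steps concerns this change. Going by the values given here, the one step known, from compound 1 to compound 2, exchanged one aromatic group for another at the same nitrogen and was within the scatter; it does not show what happens when the aromatic ring leaves altogether and a short chain enters. The expectation therefore rests on the weak level of both measured compounds and allows no firm direction; a step of no more than the scatter, or a modest move to a higher number, is the most that can be said, and the range is kept wide.

On this basis compound 3 is expected to give 90000 nM in this assay, between 35000 nM and 250000 nM, which corresponds to an estimated step of a 2.2-fold higher number from compound 2 to compound 3 (0.35 log units; beyond the scatter).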

Compound 3, half-maximal inhibitory concentration: 92500 nM
Compound 3: middle estimate off by 1.0-fold (0.01 log units), on the low side, within the range that was stated.
By their numbers in this assay, from the lowest: compounds 2, 1 and 3 (each within the scatter of the next, the first and the last beyond it).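

In this assay, for the compounds shown here, (ethoxycarbonyl)methyl in place of 3,4,5-trimethoxyphenyl on this nitrogen gives a 2.3-fold higher number from compound 2 to compound 3 (0.36 log units; beyond the scatter), a modest step, and it is the first change at this position that lies beyond the scatter. Read the other way, ethoxycarbonyl in place of 3-methoxyphenyl on a saturated chain carbon bound to a nitrogen on an aromatic ring gives a 1.1-fold higher number from compound 1 to compound 3 (0.06 log units; within the scatter), so compound 1 and compound 3 cannot be ordered, and an aromatic ring at this position does not by itself separate a compound from the ring-free chain: only compound 2 stands apart from compound 3, while compound 1, which also carries a ring, goes against any such rule. Going by these compounds alone, nothing at hand explains why the one pair differs and the other does not.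

The compounds shown leave open whether a plain phenyl group on this nitrogen would stand with compound 2 or with compound 1, which would tell whether the three methoxy groups matter. They also leave open how a carboxylic acid in place of the ethyl ester of the chain, or a simple amine at the end of a longer chain, would read in this assay.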